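The source may hold more compounds than are shown below. What is called first, only, known or untested is meant among the compounds shown, and "the series" means these compounds.

Within the data shown here, compound 1 `O=C1Nc2ccccc2/C1=C\c1c(Cl)n(Cc2ccccc2)c2ccccc12` is one of three compounds measured in a functional assay on cells (Cancer cell lines, Homo sapiens) for cytotoxicity, with a stated time of 48 h; a higher number here means a weaker inhibitor of growth, a lower number a stronger inhibitor of growth. In this assay compound 1 gives 12900 nM, the highest of the three numbers. Compound 2 `O=C1/C(=C/c2c(Cl)[nH]c3ccccc23)c2ccccc2N1Cc1ccccc1` gives 4170 nM, a lower number that lies beyond the scatter of compound 1. Compound 3 `COc1cc2c(/C=C3/C(=O)Nc4cccc(Cl)c43)c(Cl)n(Cc3cc(OC)c(OC)c(OC)c3)c2cc1C` gives 2950 nM, also lower and beyond the scatter. Among the measured compounds shown here, compound 1 thus stands as the weakest inhibitor of growth among the three; compounds 2 and 3 differ from it in more than one place, so no single step between measured compounds is available.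

Compound 4 `O=C1Nc2ccccc2/C1=C\c1c(Cl)n(CCCc2ccccc2)c2ccccc12` is not yet measured. It differs from compound 1 in one place: phenethyl in place of phenyl on a saturated chain carbon bound to an aromatic nitrogen. Nothing in the measured compounds shows how lengthening this chain affects the read-out. Compound 4 is therefore expected to sit close to compound 1, with a step of a 1.3-fold lower number from compound 1 to compound 4 (0.11 log units; within the scatter) that may not exceed the scatter in either direction. On that basis compound 4 is estimated to give 10000 nM, within a range from 3500 nM to 30000 nM.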

Compound 4, concentration for 50% growth inhibition: 10000 nM
For compound 4 middle estimate and measured number coincide at the digits printed; low and high end bracket the measured number.
By their numbers in this assay, from the lowest: compounds 3 and 2 (each within the scatter of the next); then compounds 4 and 1 (each within the scatter of the next).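

With the chain carbon bound to the aromatic nitrogen as the point of change, phenethyl in place of phenyl, which also reads as benzyl to 3-phenylpropyl, gives in this assay a 1.3-fold lower number from compound 1 to compound 4 (0.11 log units; within the scatter) and leaves compound 4 indistinguishable from compound 1. Among these compounds, this is the first single-place comparison, and it shows that this position tolerates this lengthening of the chain with the terminal phenyl ring kept and no measurable gain or loss in growth inhibition. No measured evidence bears on why the two compounds read alike.

On these data alone, whether an amine or a carboxylic acid on the chain in place of the terminal phenyl, or a still longer chain, would read the same remains open. So does the outcome of a plain methyl on that nitrogen, with the core of compound 1 kept.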